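The compounds below may be only part of what the source reports. "The series", "measured", "known", "first", "only" and "open" are said of these compounds alone.

Working notes on the series, read in a functional assay on K562 cells (Homo sapiens) for cytotoxicity, read by trypan blue exclusion, with a stated time of 96 h; on this read-out lower numbers stand for stronger inhibition and higher numbers for weaker inhibition. Compound 1 `COc1cc(OC)c(/C=C/S(=O)(=O)Cc2ccc(OC)c(N)c2)c(OC)c1` gives 2.5 nM, compound 2 `COc1cc(OC)c(/C=C/S(=O)(=O)Cc2cc(N)ccc2OC)c(OC)c1` gives 7500 nM, and compound 3 `COC(=O)CCNc1cc(CS(=O)(=O)/C=C/c2c(OC)cc(OC)cc2OC)ccc1OC` gives 1000 nM. Compound 3 therefore holds the second highest of the three numbers, much closer to compound 2 than to compound 1.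

The next compound is compound 4 `COC(=O)C(C)(C)Nc1cc(CS(=O)(=O)/C=C/c2c(OC)cc(OC)cc2OC)ccc1OC`. The change is 1-(methoxycarbonyl)-1-methylethyl in place of 2-(methoxycarbonyl)ethyl on a nitrogen on an aromatic ring; in words, 1-(methoxycarbonyl)-1-methylethyl in place of 2-(methoxycarbonyl)ethyl on a nitrogen on an aromatic ring.

Two measured steps give context. The step of a 400-fold higher number from compound 1 to compound 3 (2.60 log units; beyond the scatter) is the closer guide, since it is made on the same nitrogen, but it adds a chain to a bare nitrogen, whereas compound 4 only exchanges one ester-bearing group for another. The step of a 3000-fold higher number from compound 1 to compound 2 (3.48 log units; beyond the scatter) concerns the 5-amino-2-methoxyphenyl exchange, which is not touched here. For the measured compounds named here, both are large, so this series can move sharply, and the data hold no direct precedent for the new group.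

Compound 4 is thus expected to stay closer to compound 3 than to compound 1, with no firm step beyond the scatter. The expected change is a 1.7-fold lower number from compound 3 to compound 4 (0.22 log units; within the scatter), leaning slightly towards a lower number. For compound 4 the estimate is 600 nM, with an expected range of 60 nM to 5000 nM.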

Compound 4, half-maximal inhibitory concentration: 800 nM
Beside the measured number, compound 4's estimate is 1.3-fold (0.12 log units) below it; the range from low to high includes it.
By their numbers in this assay, from the lowest: compound 1; then compounds 4 and 3 (each within the scatter of the next); then compound 2.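

In this assay, 1-(methoxycarbonyl)-1-methylethyl in place of 2-(methoxycarbonyl)ethyl on a nitrogen on an aromatic ring gives a 1.3-fold lower number from compound 3 to compound 4 (0.10 log units; within the scatter), so the two ester-bearing groups, of 7 and 6 heavy atoms, cannot be told apart at this position. Replacing the hydrogen on this nitrogen now carries a large step with a second group, as a 320-fold higher number from compound 1 to compound 4 (2.51 log units; beyond the scatter) stands alongside a 400-fold higher number from compound 1 to compound 3 (2.60 log units; beyond the scatter), so the large loss is not confined to a single ester-bearing chain. No supporting data bear on what lies behind these numbers.

Open, going by these compounds, is whether a carboxylic acid in place of the methyl ester, an amide, or a plain methyl or ethyl group on this nitrogen would stay with compound 3 and compound 4 or move towards compound 1 at 2.5 nM. Also open is whether a longer ester-bearing chain on this nitrogen would leave the number in the same range, since the two groups shown say little about chains beyond them.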